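A few compounds are considered here, and "the series" means these few. Any claim that something is new, unique, unknown or untested is made for them only; others in the source may bear on it.

Compound 1 `OCc1cn(Cc2ccccc2)c2ccccc12` is the reference point of this small series. Going by the values given here, in an ADME assay on T29 cells (Homo sapiens) for cytotoxicity, read by sulforhodamine B assay, with a stated time of 3 days (on this read-out lower numbers stand for stronger inhibition and higher numbers for weaker inhibition), compound 1 gives 14500 nM, the only plain number reported for the series. Compound 2 `OCc1cn(Cc2cccc(Cl)c2)c2ccccc12` carries a chloro in place of hydrogen on an aromatic carbon. In this assay compound 2 gives only > 31600 nM, which is a limit of the assay rather than a number. The step of an at least 2.1-fold higher number from compound 1 to compound 2 (0.33 log units; beyond the scatter) is therefore known only as a floor, set by the limit of > 31600 nM in this assay, at which 1 of the 2 values shown sits. Compound 3 `OCc1cn(Cc2ccc(Br)cc2)c2ccccc12` differs from compound 1 by bromo in place of hydrogen on an aromatic carbon. Among the compounds with values here, the sole measured step that bears on it is an at least 2.1-fold higher number from compound 1 to compound 2 (0.33 log units; beyond the scatter), in which a halogen likewise replaced a hydrogen. On that basis a rise of similar or greater size is expected in this assay, most likely ending at the same limit. The estimate for compound 3 is 32000 nM, with a range from 12000 nM to 90000 nM. The expected step is a 2.2-fold higher number from compound 1 to compound 3 (0.34 log units; beyond the scatter), upward.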

Compound 3, half-maximal inhibitory concentration: > 31600 nM
Compound 3 was reported as a limit (the forecaster's own chance of this, stated with the estimate: 55%); the middle value is on the limit's open side.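

The bromo in place of hydrogen, on an aromatic carbon para to a large group, gives an at least 2.1-fold higher number from compound 1 to compound 3 (0.33 log units; beyond the scatter) in this assay and so moves the number in the same direction as the chloro of compound 2. With this second halogen, the rise from compound 1 no longer rests on a single replacement, and neither of the two halogen-bearing compounds shown goes against it. From the compounds shown here alone, the reading for compound 3 is a limit and not a number, so the full size of the rise stays unknown, and chloro and bromo cannot be ordered against each other, because both compounds stop at the same ceiling: the limit of > 31600 nM in this assay, at which 2 of the 3 values shown sit.

The compounds shown leave open whether this rise belongs to halogens alone or would also appear with a methoxy group, an amine or a carboxylic acid at the same place on the ring. They also leave open whether any replacement there would give a lower number than compound 1, and what would follow if the hydroxymethyl group of the shared core gave way to a longer chain or an amide.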